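Methoxy step on a piperazinyl phenyl in cytotoxicity

A few compounds are considered here, and "the series" means these few. Any claim that something is new, unique, unknown or untested is made for them only; others in the source may bear on it.

Measured compounds:
compound 1 `Clc1ccc(-c2csc3ncnc(N4CCN(c5ccccc5)CC4)c23)cc1` — 34.2 nM
compound 2 `COc1ccc(N2CCN(c3ncnc4scc(-c5ccc(Cl)cc5)c34)CC2)cc1` — 48.5 nM
compound 3 `O=[N+]([O-])c1ccc(-c2csc3ncnc(N4CCN(c5ccccc5)CC4)c23)cc1` — 28.7 nM

Compound 1, compound 2 and compound 3 share a core and were tested in a functional assay on MCF7 cells (Homo sapiens) for cytotoxicity, read by sulforhodamine B assay, with a stated time of 48 h; a higher number here means a weaker inhibitor, a lower number a stronger inhibitor. Compound 2 carries the change methoxy in place of hydrogen on an aromatic carbon relative to compound 1, and the step of a 1.4-fold higher number from compound 1 to compound 2 (0.15 log units; within the scatter) shows the number moved only slightly. Compound 3 differs from compound 1 by nitro in place of chloro on an aromatic carbon, with a step of a 1.2-fold lower number from compound 1 to compound 3 (0.08 log units; within the scatter). Compound 3 has the lowest number of the three, but its gaps to compound 1 and to compound 2 are within the scatter, so no order among the three is claimed.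

Compound 4 `COc1ccc(N2CCN(c3ncnc4scc(-c5ccc([N+](=O)[O-])cc5)c34)CC2)cc1` is not yet measured in this assay. Among the measured compounds shown here, it differs from compound 3 by methoxy in place of hydrogen on an aromatic carbon, which is the same change as the one from compound 1 to compound 2, at the same place. The two cores differ by nitro in place of chloro on an aromatic carbon. Since the change is the same and the place is the same, the step from compound 3 to compound 4 is expected to resemble the earlier one: a step of about a 1.4-fold higher number from compound 3 to compound 4 (0.14 log units; within the scatter) is estimated, resting on the step of a 1.4-fold higher number from compound 1 to compound 2 (0.15 log units; within the scatter) seen on the other core. Compound 4 is therefore estimated at 40 nM, with a range from 22 nM to 75 nM, since a single precedent on a different core leaves room for ordinary scatter.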

Compound 4, half-maximal inhibitory concentration: 36.9 nM
For compound 4 the middle estimate is 1.1-fold (0.04 log units) above the measured one, and the stated range covers the measured number.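

In this assay, the step phenyl to 4-methoxyphenyl gives a 1.3-fold higher number from compound 3 to compound 4 (0.11 log units; within the scatter), and it agrees with its counterpart on the core of compound 1: the same change on two cores in this assay, a 1.4-fold higher number (0.15 log units; within the scatter) from compound 1 to compound 2 and a 1.3-fold higher number (0.11 log units; within the scatter) from compound 3 to compound 4, 1.1-fold (0.04 log units) apart, within the scatter of two such steps

Read the other way round the square, nitro in place of chloro gives a 1.3-fold lower number from compound 2 to compound 4 (0.12 log units; within the scatter), which also agrees with its earlier reading: the same change on two cores in this assay, a 1.2-fold lower number (0.08 log units; within the scatter) from compound 1 to compound 3 and a 1.3-fold lower number (0.12 log units; within the scatter) from compound 2 to compound 4, 1.1-fold (0.04 log units) apart, within the scatter of two such steps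

Among the compounds shown here, the two changes therefore carry from one core to the other without a visible difference in this set of four compounds, but all of these steps lie within the scatter, so this shows only that small steps stayed small, not that either change itself moves the number, nor that a larger step would carry over in the same way.

The compounds shown offer only hydrogen and methoxy at the one place and only chloro and nitro at the other, so a step beyond the scatter has yet to be seen in this square. From the compounds shown here alone, whether an amine, a carboxylic acid or a longer chain such as ethoxy at the methoxy place would give such a step, and whether that step would then hold on both cores, stays open.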